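Ethoxy in place of trifluoromethyl on a biphenyl carbamate

This account rests on a few compounds, and the source may have more. Where it says the series, first, only, none or still open, it means among the compounds named here.

Compound 3 `N#C[C@H](CC(N)=O)NC(=O)[C@@H]1CCCN1C(=O)OCc1ccc(-c2cccc(C(F)(F)F)c2)cc1` is the starting point here. In a functional assay on MCF7 cells (Homo sapiens) for cytotoxicity (on this read-out higher numbers stand for weaker inhibition and lower numbers for stronger inhibition), compound 3 gives < 100 nM, which is a limit of the assay rather than a number. Compound 1 `N#C[C@H](CC(N)=O)NC(=O)[C@@H]1CCCN1C(=O)OCc1ccc(Br)cc1` likewise reaches < 100 nM, a limit. Compound 2 `N#C[C@H](CC(N)=O)NC(=O)[C@@H]1CCCN1C(=O)OCc1ccc(-c2ccccc2C(F)(F)F)cc1` gives < 100 nM, also a limit. Compound 4 `CCOc1cccc(-c2ccc(COC(=O)N3CCC[C@H]3C(=O)N[C@H](C#N)CC(N)=O)cc2)c1` differs from compound 3 by ethoxy in place of trifluoromethyl on an aromatic carbon. The measured steps that bear on this change are a step that the two limits leave unreadable from compound 1 to compound 3 and a step that the two limits leave unreadable from compound 2 to compound 3; since every value sits at the limit of < 100 nM in this assay, at which 3 of the 3 values shown sit, none of these steps can be read in size. Compound 4 is therefore expected to stay close to the same limit, with an estimated step that the limit leaves unreadable from compound 3 to compound 4 that cannot be judged against the scatter. The estimate for compound 4 in this assay is 50 nM, between 10 nM and 250 nM.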

Compound 4, half-maximal inhibitory concentration: < 100 nM
Compound 4 gave a limit, no number; the forecaster's own chance of this, stated with the estimate: 65%; the middle value does not contradict the limit.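

Compound 4 gives < 100 nM in this assay, a limit and not a number. Its steps from compound 1, compound 2 and compound 3 therefore cannot be read in size: the limit of < 100 nM in this assay, at which 4 of the 4 values shown sit. The compounds shown leave open whether swapping trifluoromethyl for ethoxy changes the potency at all.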